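The source may report more compounds than this note shows. Statements on the series, on what has been measured and on what is new or still open speak of the compounds shown alone.

This account follows one change within a small set of antiproliferative compounds. Among the compounds with values here, in an ADME assay on L02 cells (Homo sapiens) for antiproliferative activity, read by CCK-8 assay, with a stated time of 6 days (on this read-out higher numbers stand for weaker inhibition and lower numbers for stronger inhibition), compound 1, `N#Cc1ccc(N2CCCc3c(-c4cccnc4)cccc32)cc1C(F)(F)F`, gives 10500 nM, the only number on hand. Compound 2, `CCN(c1ccc(C#N)c(Cl)c1)c1cc(-c2cccs2)ccc1C`, has in this assay the entry "not determined" (no result reported), so there is no single number to set it against compound 1. Compound 3, `CCN(c1ccc(C#N)c(Cl)c1)c1cc(-c2ccccc2)ccc1C`, has yet to be tested. The change from compound 2 to compound 3 is phenyl in place of thiophen-2-yl on an aromatic carbon. Within the data shown here, with no measured step for this pair, no direction can be read from the numbers; the expectation is for a change in this assay that stays within the usual scatter, neither clearly stronger nor clearly weaker. Taking the weak inhibition of compound 1 as the only anchor, compound 3 is estimated at 12000 nM, with a range from 3000 nM to 50000 nM in this assay.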

Compound 3, half-maximal inhibitory concentration: > 30000 nM
Compound 3 ended at the assay's limit; the forecaster's own chance of this, stated with the estimate: 35%; middle value at least 2.5-fold (0.39 log units) from the limit.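

In this assay compound 3 gives > 30000 nM, which is a limit and not a number. Within the data shown here, compound 2 has no single number there, and no step from compound 2 to compound 3 can be read. The compounds shown leave open whether phenyl and thiophen-2-yl differ at all on this read-out.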